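The source may hold more compounds than are shown below. What is called first, only, known or untested is meant among the compounds shown, and "the series" means these compounds.

Compound 1 `CC(C)[C@@H](c1ccc(-c2ccc3cccc(F)c3c2)[nH]c1=O)[C@@H]1OC(=O)NC1=O` belongs to a small set of molecules built around a shared core and tested in a functional assay on CHO cells for antagonist activity at prostaglandin E2 receptor EP3 subtype (Homo sapiens), read by cAMP accumulation, with a stated time of 30 min; on this read-out lower numbers stand for stronger inhibition and higher numbers for weaker inhibition. In this assay compound 1 gives 610 nM, the highest number among the two compounds with a result and therefore the weakest inhibitor of the two. Compound 3 `CC(C)C(/C=C1/C(=O)NC(=O)N1C)c1ccc(-c2ccc3cccc(F)c3c2)[nH]c1=O`, which carries a different ring on a different linker, gives 11 nM, a far lower number, and the gap between compound 1 and compound 3 lies well beyond the usual scatter. Compound 2 `CCC(/C=C1\OC(=O)NC1=O)(CC)c1ccc(-c2ccc3cccc(C(C)C)c3c2)[nH]c1=O` has no result in this assay, recorded as "not determined" (no result reported).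

Compound 4 `CC(C)[C@H](C[C@@H]1OC(=O)NC1=O)c1ccc(-c2ccc3cccc(F)c3c2)[nH]c1=O` differs from compound 1 in one place: (2,4-dioxo-1,3-oxazolidin-5-yl)methyl in place of 2,4-dioxo-1,3-oxazolidin-5-yl on a saturated chain carbon bound to an aromatic carbon and a saturated chain carbon. The ring itself is unchanged; only one chain carbon is inserted between it and the rest of the molecule. Going by the values given here, no measured pair in this set shows the effect of such an insertion, so the direction can only be estimated. The step from compound 1 to compound 4 in this assay is expected to be small, a 2.0-fold lower number from compound 1 to compound 4 (0.31 log units; beyond the scatter), likely within or just beyond the scatter. Compound 4 is therefore estimated at 300 nM, with a range from 60 nM to 1500 nM.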

Compound 4, half-maximal inhibitory concentration in the prostaglandin E2 receptor EP3 subtype assay: 27 nM
The estimate for compound 4 lay 11-fold (1.05 log units) above the measured number; measured number outside the range, below it.
By their numbers in the prostaglandin E2 receptor EP3 subtype assay, from the lowest: compound 3; then compound 4; then compound 1.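

At this saturated chain carbon, the length of the link to the ring matters greatly: in the prostaglandin E2 receptor EP3 subtype assay, compound 1 gives 610 nM and compound 4 gives 27 nM, so that (2,4-dioxo-1,3-oxazolidin-5-yl)methyl in place of 2,4-dioxo-1,3-oxazolidin-5-yl gives a 23-fold lower number from compound 1 to compound 4 (1.35 log units; beyond the scatter) and so, with the ring itself unchanged, one inserted chain carbon yields a much stronger inhibitor. In a physicochemical assay for solubility, in phosphate buffer, measured as kinetic solubility (a lower number here means a less soluble compound, a higher number a more soluble compound), compound 1 gives 27400 nM and compound 4 gives 21100 nM, and the same change gives a 1.3-fold lower number from compound 1 to compound 4 (0.11 log units; within the scatter) and stays within the usual scatter, so the large gain in inhibition comes with no measurable loss of solubility. No measured evidence is available to explain why the inserted carbon has this effect.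

From the compounds shown here alone, whether a longer chain, such as (2,4-dioxo-1,3-oxazolidin-5-yl)ethyl, would strengthen inhibition further remains open. Also open, going by these compounds, is whether a carboxylic acid could take the place of the ring at the end of the chain and keep this inhibition.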